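The source may hold more compounds than are shown below. What is called first, only, known or untested is meant among the compounds shown, and "the series" means these compounds.

Compound 3 `CCOC(=O)C1=Cc2ccccc2OC1(OCc1cn(-c2ccccc2)nn1)C(F)(F)F` stands at the edge of what a functional assay on DU-145 cells (Homo sapiens) for inhibition, read by MTT assay, with a stated time of 24 h (on this read-out higher numbers stand for weaker inhibition and lower numbers for stronger inhibition), can report: in this assay compound 3 gives only > 150000 nM, a limit rather than a number. Compound 2 `CCOC(=O)C1=Cc2ccccc2OC1(OCc1cn(-c2cccc(OC)c2)nn1)C(F)(F)F` likewise reaches only a limit, > 150000 nM. a step that the two limits leave unreadable from compound 2 to compound 3, both values being covered by the limit of > 150000 nM in this assay, at which 2 of the 3 values shown sit. Compound 1 `CCOC(=O)C1=Cc2ccccc2OC1(OCc1cn(CC(=O)Nc2cccc(Cl)c2)nn1)C(F)(F)F`, carrying ((3-chlorophenyl)carbamoyl)methyl on the aromatic nitrogen, gives 10100 nM, so that an at least 14-fold higher number from compound 1 to compound 3 (1.17 log units; beyond the scatter) and an at least 14-fold higher number from compound 1 to compound 2 (1.17 log units; beyond the scatter). Compound 4 `CCOC(=O)C1=Cc2ccccc2OC1(OCc1cn(CC(=O)Nc2ccccc2F)nn1)C(F)(F)F` differs from compound 3 by ((2-fluorophenyl)carbamoyl)methyl in place of phenyl on an aromatic nitrogen. As this largely reverses the measured step of an at least 14-fold higher number from compound 1 to compound 3 (1.17 log units; beyond the scatter), a large drop in this assay is expected, an at least 10-fold lower number from compound 3 to compound 4 (1.00 log units; beyond the scatter). Compound 4 is therefore estimated at about 15000 nM, within a range from 4000 nM to 60000 nM.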

Compound 4, half-maximal inhibitory concentration: 33900 nM
Estimate against measurement, compound 4: 2.3-fold (0.35 log units) below; measured number inside the range.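

With ((2-fluorophenyl)carbamoyl)methyl on the aromatic nitrogen, compound 4 also gives a measurable value in this assay, with an at least 4.4-fold lower number from compound 3 to compound 4 (0.64 log units; beyond the scatter) and an at least 4.4-fold lower number from compound 2 to compound 4 (0.64 log units; beyond the scatter), so a measurable value on this position is not confined to the 3-chlorophenyl amide of compound 1. Both steps give only a lower bound on size, since compound 2 and compound 3 each sit at a limit: the limit of > 150000 nM in this assay, at which 2 of the 4 values shown sit. The aryl group on the amide nitrogen also shifts the value, with a 3.4-fold higher number from compound 1 to compound 4 (0.53 log units; beyond the scatter).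

From the compounds shown here alone, it remains open whether the halogen itself or its place on the ring sets this step. Also open, going by these compounds, is how a carboxylic acid or an amine in place of ((2-fluorophenyl)carbamoyl)methyl would read.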